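Swapping a Sulfonyl Group for a Chloropyrimidine

The compounds below may be only part of what the source reports. "The series", "measured", "known", "first", "only" and "open" are said of these compounds alone.

Of the compounds shown here, three sharing one core have been measured in a functional assay on LNCaP cells (Homo sapiens) for antiproliferative activity, read by CCK-8 assay, with a stated time of 6 days; on this read-out lower numbers stand for stronger inhibition and higher numbers for weaker inhibition. Compound 1 `CC(O)c1ccc(C(=O)N[C@@H](C)Cn2ccc(-c3ccc(C#N)c(Cl)c3)n2)cc1` gives 3690 nM. Compound 2 `C[C@@H](Cn1ccc(-c2ccc(C#N)c(Cl)c2)n1)NS(=O)(=O)c1cccnc1` gives 6140 nM, the highest number of the three; its gap to compound 1 lies within the scatter of the assay, so the two cannot be told apart, while compound 3 `C[C@@H](Cn1ccc(-c2cc(F)c(C#N)c(Cl)c2)n1)NC(=O)Nc1cc(C(C)(C)C)[nH]n1`, which gives 1630 nM, sits clearly lower and so beyond the scatter.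

Compound 4 `C[C@@H](Cn1ccc(-c2ccc(C#N)c(Cl)c2)n1)Nc1nccc(Cl)n1` has not yet been measured. It differs from compound 2 in one place: 4-chloropyrimidin-2-yl in place of (pyridin-3-yl)sulfonyl on an amine nitrogen. Going by the values given here, no measured pair shows this exact change, so there is no direct guide to its size. The measured compounds show that exchanging the group on this amine nitrogen moves the number only moderately, and the direction here is uncertain. Compound 4 is therefore expected to land near compound 2, with the step of a 2.0-fold lower number from compound 2 to compound 4 (0.31 log units; beyond the scatter) estimated as small and possibly within the scatter. The estimate for compound 4 in this assay is 3000 nM, with a range from 700 nM to 12000 nM.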

Compound 4, half-maximal inhibitory concentration: 1400 nM
The estimate for compound 4 lay 2.1-fold (0.33 log units) above the measured number; the measured number falls inside the stated range.
By their numbers in this assay, from the lowest: compounds 4 and 3 (each within the scatter of the next); then compounds 1 and 2 (each within the scatter of the next).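

In this assay, replacing (pyridin-3-yl)sulfonyl with 4-chloropyrimidin-2-yl on the amine nitrogen gives a 4.4-fold lower number from compound 2 to compound 4 (0.64 log units; beyond the scatter). Going by these compounds alone, this is the first measured change made in one place only, and it shows that the group on this nitrogen can shift the number by more than the usual scatter, even with the rest of the molecule unchanged. Nothing here accounts for the size of this step, so it stands as an observation without a known cause.

The compounds shown leave open whether the step depends on the chlorine or on the pyrimidine ring itself; a plain pyrimidin-2-yl or a 4-aminopyrimidin-2-yl group on the same nitrogen would separate the two. As far as these compounds go, it also remains open whether the same swap would have a similar effect on the fluorine-bearing core of compound 3.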